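The source may hold more compounds than are shown below. What is called first, only, known or untested is meant among the compounds shown, and "the series" means these compounds.

Measured in a physicochemical assay for solubility; on this read-out lower numbers stand for lower solubility and higher numbers for higher solubility:
Compound 1 (`O=C([C@@H]1CCCN1C(=O)c1ccncc1)N1CCC(NS(=O)(=O)c2cc(S(=O)(=O)c3ccccc3)ccc2C(F)(F)F)CC1`): 100000 nM
Compound 2 (`O=C([C@@H]1CCCN1C(=O)Nc1ccccc1)N1CCC(NS(=O)(=O)c2cc(S(=O)(=O)c3ccccc3)ccc2C(F)(F)F)CC1`): 25000 nM

Compound 2 has the lower of the two numbers in this assay, at 25000 nM. Compound 3 (`CN(C)C(=O)N1CCC[C@H]1C(=O)N1CCC(NS(=O)(=O)c2cc(S(=O)(=O)c3ccccc3)ccc2C(F)(F)F)CC1`) puts dimethylamino in place of anilino on a carbonyl carbon. Among the compounds with values here, only one measured step bears on this carbonyl carbon, the modest 4.0-fold lower number from compound 1 to compound 2 (0.60 log units; beyond the scatter), which brought anilino in. From the compounds shown here alone, with anilino leaving, a step of similar size towards a higher number is expected, though dimethylamino itself is untested. The expected step is a 2.4-fold higher number from compound 2 to compound 3 (0.38 log units; beyond the scatter). For compound 3 the estimated value is 60000 nM, with an expected range of 30000 nM to 120000 nM.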

Compound 3, solubility: 100000 nM
Compound 3: the middle estimate sits 1.7-fold (0.22 log units) below what was measured, and the stated range covers the measured number.
By their numbers in this assay, from the lowest: compound 2; then compounds 1 and 3 (each within the scatter of the next).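

In this assay, the change to dimethylamino on this carbonyl carbon gives a 4.0-fold higher number from compound 2 to compound 3 (0.60 log units; beyond the scatter) and, set against pyridin-4-yl, no change at the digits printed from compound 1 to compound 3 (within the scatter) on the shared core. Of the three groups read at this position, anilino alone stands apart, with the lower number, while dimethylamino and pyridin-4-yl are not separated. Nothing given here accounts for this difference.

From the compounds shown here alone, whether the lower number goes with the aromatic ring of anilino or with its amide hydrogen stays open, as the two leave together. Methylamino on the same carbonyl carbon would keep that hydrogen without the ring.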